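Swapping the aryl group on the core toward a halogenated phenyl

A few compounds are considered here, and "the series" means these few. Any claim that something is new, unique, unknown or untested is made for them only; others in the source may bear on it.

Measured compounds in a functional assay on NCI-H460 cells (Homo sapiens) for antiproliferative activity, read by MTT assay, with a stated time of 72 h; on this read-out lower numbers stand for stronger inhibition and higher numbers for weaker inhibition:
compound 1, `CNC(=O)c1cc(Oc2ccc(NC(=O)c3cc4cccnc4n(-c4ccccc4)c3=O)cc2)ccn1`, 320 nM
compound 2, `CNC(=O)c1cc(Oc2ccc(NC(=O)c3cc4cccnc4n(-c4ccccc4F)c3=O)cc2)ccn1`, 590 nM
compound 3, `CNC(=O)c1cc(Oc2ccc(NC(=O)c3cc4cccnc4n(-c4ccc(OC)cc4)c3=O)cc2)ccn1`, "not determined" (no result reported)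

Compound 3 therefore stands nowhere on the numbers shown: the set gives no value for it in this assay, and its position can only be read through its neighbours. Compound 4, `CNC(=O)c1cc(Oc2ccc(NC(=O)c3cc4cccnc4n(-c4ccc(C(F)(F)F)cc4Cl)c3=O)cc2)ccn1`, differs from compound 3 in one place: 2-chloro-4-(trifluoromethyl)phenyl in place of 4-methoxyphenyl on an aromatic nitrogen. Within the data shown here, no measured step covers this change. Among the measured compounds shown here, the only step that bears on the aryl group at this aromatic nitrogen is a 1.8-fold higher number from compound 1 to compound 2 (0.27 log units; within the scatter), and it stayed within the scatter. That step concerns a single fluoro at the aryl ring, so it speaks only loosely to a change that brings in a chloro and a trifluoromethyl at once. On this basis the expectation for compound 4 in this assay is a number close to those of compound 1 and compound 2, with no step beyond the scatter anticipated in either direction, though the range must stay wide. The estimate for compound 4 is 450 nM, expected to fall between 150 nM and 1400 nM.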

Compound 4, half-maximal inhibitory concentration: 2110 nM
Compound 4: middle estimate off by 4.7-fold (0.67 log units), on the low side, outside the stated range (above it).
By their numbers in this assay, from the lowest: compounds 1 and 2 (each within the scatter of the next); then compound 4.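

In this assay the aryl group on the aromatic nitrogen can shift the number beyond the scatter: with 2-chloro-4-(trifluoromethyl)phenyl in place of phenyl there is a 6.6-fold higher number from compound 1 to compound 4 (0.82 log units; beyond the scatter) and with the same group in place of 2-fluorophenyl there is a 3.6-fold higher number from compound 2 to compound 4 (0.55 log units; beyond the scatter) in the same direction. Both steps are modest, but the earlier single fluoro change stayed within the scatter, so this is the first change shown at this position to weaken inhibition beyond it. No measurement at hand says what lies behind this weaker inhibition.

The compounds shown leave open whether the chloro or the trifluoromethyl carries the step, as the two enter together, and the steps from compound 3 cannot be read, as it has no number in this assay to place its 4-methoxyphenyl. They also leave open how an amine or a carboxylic acid on this aryl ring would read.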